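The compounds below may be only part of what the source reports. "The series", "measured", "known", "first", "only" and "open" are said of these compounds alone.

Measured so far in an in vitro functional assay on cells for antagonist activity at B1 bradykinin receptor (Homo sapiens), read by luminescence and calcium flux, with a stated time of 2 h; a lower number here means a stronger inhibitor, a higher number a weaker inhibitor:
compound 1, `Cc1ccc(S(=O)(=O)N2C=CNC(=O)[C@H]2CC(=O)N[C@@H]2CCCc3cc(CN4CCCCC4)ccc32)cc1`, 0.115 nM
compound 2, `Cc1ccc(S(=O)(=O)N2C=CNC(=O)[C@H]2CC(=O)N[C@@H]2CCCc3ccccc32)cc1`, 3.3 nM
compound 3, `Cc1ccc(S(=O)(=O)N2C=CNC(=O)[C@H]2CC(=O)N[C@@H]2CCC(O)c3ccccc32)cc1`, 1.47 nM

Of these three, compound 2 gives the highest number in this assay, so it is the weakest inhibitor shown. Its nearest neighbour is compound 3, reached by a 2.2-fold lower number from compound 2 to compound 3 (0.35 log units; beyond the scatter). The furthest is compound 1, from which the change to compound 2 is a 29-fold higher number from compound 1 to compound 2 (1.46 log units; beyond the scatter).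

Compound 4, `Cc1ccc(S(=O)(=O)N2C=CNC(=O)[C@H]2CC(=O)NC2CCCCC2)cc1`, has not yet been measured. It differs from compound 2 in one place: cyclohexyl in place of 1,2,3,4-tetrahydronaphthalen-1-yl on an amide-type nitrogen. Both measured steps touch the same region: the large loss from compound 1 to compound 2 came from stripping a substituent off the aromatic ring of that group, and the modest gain from compound 2 to compound 3 came from a hydroxy on its saturated ring. Among the measured compounds shown here, neither step removes the aromatic ring itself, so there is no direct precedent for the change to compound 4. Since every alteration of this group so far has moved the number beyond the scatter, and the present one is the deepest cut, a weakening step is expected, estimated as a 15-fold higher number from compound 2 to compound 4 (1.18 log units; beyond the scatter). Compound 4 is therefore expected to give about 50 nM, within a range of 8 nM to 400 nM.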

Compound 4, half-maximal inhibitory concentration: 990 nM
The estimate for compound 4 lay 20-fold (1.30 log units) below the measured number; the measured number lies above the stated range.
By their numbers in this assay, from the lowest: compound 1; then compound 3; then compound 2; then compound 4.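

In this assay, the step of a 300-fold higher number from compound 2 to compound 4 (2.48 log units; beyond the scatter) is larger than either earlier change to this group, a 29-fold higher number from compound 1 to compound 2 (1.46 log units; beyond the scatter) and a 2.2-fold lower number from compound 2 to compound 3 (0.35 log units; beyond the scatter), so replacing the whole group matters more here than adding or removing a substituent on it. The change leaves a six-membered non-aromatic ring of carbon only on the amide-type nitrogen but loses the six-membered aromatic ring and the defined stereocentre of 1,2,3,4-tetrahydronaphthalen-1-yl. A saturated carbon ring alone on this nitrogen therefore does not hold the level of compound 2, although this single swap cannot show which lost feature counts, since the aromatic ring, the stereocentre and the heavy-atom count all change together.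

Nothing available explains why the number rises so steeply. A benzyl or phenyl group on the same nitrogen would restore an aromatic ring without the saturated ring, and the compounds shown leave open how much of the lost inhibition such a group would recover.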